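Methoxy in place of nitro: expected tolerance for compound 4

The source may report more compounds than this note shows. Statements on the series, on what has been measured and on what is new or still open speak of the compounds shown alone.

Three compounds have been measured in an ADME assay on MDBK cells (Bos taurus) for cytotoxicity, read by MTT assay, with a stated time of 96 h; a higher number here means that more compound is tolerated, a lower number that less compound is tolerated:
- compound 1 `Oc1ccc(-c2nc3cc(C(F)(F)F)ccc3[nH]2)cc1` gives 51000 nM.
- compound 2 `O=C(O)CCC(=O)Nc1ccc(-c2nc3cc(C(F)(F)F)ccc3[nH]2)cc1` gives only a limit, > 100000 nM, which is the limit of > 100000 nM in this assay, at which 1 of the 3 values shown sits.
- compound 3 `O=[N+]([O-])c1ccc(-c2nc3cc(C(F)(F)F)ccc3[nH]2)cc1` gives 6000 nM.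

Compound 3 stands lowest of the two numbers in this assay; its nearest neighbour is compound 1, with an 8.5-fold lower number from compound 1 to compound 3 (0.93 log units; beyond the scatter), while an at least 16-fold lower number from compound 2 to compound 3 (1.22 log units; beyond the scatter). Compound 4 `COc1ccc(-c2nc3cc(C(F)(F)F)ccc3[nH]2)cc1` differs from compound 3 in one place: methoxy in place of nitro on an aromatic carbon. Going by the values given here, the step that bears on this is the one from compound 1 to compound 3, where hydroxy was replaced by nitro and the number fell. Reversing the nitro to a small oxygen group is therefore expected to raise the number again, by roughly that amount. Compound 4 is estimated at 40000 nM, between 12000 nM and 100000 nM, which means an expected step of a 6.7-fold higher number from compound 3 to compound 4 (0.82 log units; beyond the scatter).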

Compound 4, half-maximal cytotoxic concentration: > 100000 nM
Compound 4: no number, only a limit (the forecaster's own chance of this, stated with the estimate: 20%); at least 2.5-fold (0.39 log units) between middle value and limit.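

In this assay compound 4 gives only a limit: the limit of > 100000 nM in this assay, at which 2 of the 4 values shown sit. Methoxy in place of nitro on this aromatic carbon gives an at least 16-fold higher number from compound 3 to compound 4 (1.22 log units; beyond the scatter), so the low tolerance of the nitro compound does not carry over to this other small group. Methyl added on the hydroxy oxygen gives an at least 1.9-fold higher number from compound 1 to compound 4 (0.29 log units; that floor lies within the scatter), which shows no clear change, and the step between the two limits cannot be read.

From the compounds shown here alone, whether an amine or a nitrile at this place would stand low like nitro or high like methoxy stays open. Going by these compounds, how far compound 4 lies past its limit also stays open.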